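Ethoxy in place of phenyl on a carbamoyl carbonyl

The source may report more compounds than this note shows. Statements on the series, on what has been measured and on what is new or still open speak of the compounds shown alone.

Compound 1 `Cc1cn([C@@H]2O[C@H](CO[Si](C)(C)C(C)(C)C)[C@@]3(OS(=O)(=O)C=C3NC(=O)NC(=O)c3ccccc3)[C@H]2O[Si](C)(C)C(C)(C)C)c(=O)n(C)c1=O` gives, in an ADME assay on HEL cells (Homo sapiens) for cytotoxicity, with a stated time of 3 days (a lower number here means that less compound is tolerated, a higher number that more compound is tolerated), only a limit, > 200000 nM. Compound 2 `Cc1cn([C@@H]2O[C@H](CO[Si](C(C)C)(C(C)C)C(C)C)[C@@]3(OS(=O)(=O)C=C3NC(=O)NC(=O)c3ccccc3)[C@H]2O[Si](C)(C)C(C)(C)C)c(=O)n(C)c1=O` likewise gives only a limit, > 100000 nM. Compound 3 `Cc1cn([C@@H]2O[C@H](COC(=O)c3ccccc3)[C@@]3(OS(=O)(=O)C=C3NC(=O)NC(=O)c3ccccc3)[C@H]2O[Si](C)(C)C(C)(C)C)c(=O)n(C)c1=O` gives 100000 nM.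

Compound 1 thus stands at a limit, and of the other two values shown, one more is also a limit. Compound 4 `CCOC(=O)NC(=O)NC1=CS(=O)(=O)O[C@@]12[C@@H](CO[Si](C)(C)C(C)(C)C)O[C@@H](n1cc(C)c(=O)n(C)c1=O)[C@@H]2O[Si](C)(C)C(C)(C)C` differs from compound 1 by ethoxy in place of phenyl on a carbonyl carbon, so benzoylcarbamoyl becomes (ethoxycarbonyl)carbamoyl. No measured step touches this carbonyl: the steps shown, a step that the two limits leave unreadable from compound 1 to compound 2 and an at least 2.0-fold lower number from compound 1 to compound 3 (0.30 log units; that floor lies within the scatter), all exchange a group on an oxygen on a saturated carbon, and none reaches beyond the scatter. No step beyond the scatter is therefore expected in this assay. Compound 4 is expected to give about 150000 nM, ranging from 60000 nM to 400000 nM. This amounts to an expected step of an at least 1.3-fold lower number from compound 1 to compound 4 (0.12 log units; that floor lies within the scatter).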

Compound 4, half-maximal cytotoxic concentration: 14000 nM
Estimate against measurement, compound 4: 11-fold (1.03 log units) above, outside the stated range (below it).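

In this assay, the group on this carbonyl carbon matters: ethoxy in place of phenyl gives an at least 14-fold lower number from compound 1 to compound 4 (1.15 log units; beyond the scatter). The earlier exchanges, all on an oxygen on a saturated carbon, showed no readable step beyond the scatter. The true size of this new step stays open because compound 1 stands at a limit, not at a number: the limit of > 200000 nM in this assay, at which 1 of the 4 values shown sits.

The compounds shown leave open whether losing the phenyl ring or bringing in the oxygen of ethoxy drives the step. An ethyl or a benzyloxy group on this carbonyl would separate the two.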